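Phenyl to 3-Methylthiophen-2-yl: Expectation for Compound 4

This account rests on a few compounds, and the source may have more. Where it says the series, first, only, none or still open, it means among the compounds named here.

Three compounds built on a shared core were tested in an assay on Sf9 cells for inhibition of protein deacetylase HDAC6 (Homo sapiens), read by fluorescence, with a stated time of 40 min, tested at 100 nM; a higher number here means more inhibition at the concentration tested (going by the name of the read-out), a lower number less inhibition. Compound 3 `O=C(NO)c1ccc(NCc2nc(-c3ccccc3)nn2-c2ccccc2)cc1` gives 72.6%, the highest of the three numbers. Compound 2 `O=C(NO)c1ccc(NCc2nc(-c3cccc(Cl)c3)nn2-c2ccccc2)cc1` gives 61.2%, and compound 1 `O=C(NO)c1ccc(NCc2nc(-c3cccc4cnccc34)nn2-c2ccccc2)cc1` gives 40.2%. Both steps that end at compound 3 went up: a number 32.4 percentage points higher from compound 1 to compound 3 (beyond the scatter) and a number 11.4 percentage points higher from compound 2 to compound 3 (beyond the scatter), while a number 21 percentage points higher from compound 1 to compound 2 (beyond the scatter).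

Compound 4 `Cc1ccsc1-c1nc(CNc2ccc(C(=O)NO)cc2)n(-c2ccccc2)n1` differs from compound 3 in one place: 3-methylthiophen-2-yl in place of phenyl on an aromatic carbon. Nothing measured here tells how a five-membered aromatic ring with one hetero atom behaves in this place, so the estimate rests on the two steps that end at compound 3. Because a number 32.4 percentage points higher from compound 1 to compound 3 (beyond the scatter) and a number 11.4 percentage points higher from compound 2 to compound 3 (beyond the scatter) both show that a group other than plain phenyl in this place gave a lower number, a modest drop is expected for compound 4, a number 12.6 percentage points lower from compound 3 to compound 4 (beyond the scatter). Compound 4 is therefore expected to give about 60% in this assay, with a likely range between 42% and 76%.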

Compound 4, a percentage reported as inhibition, at one concentration (the size of the read-out at that concentration, not a potency): 72.1%
Beside the measured number, compound 4's estimate is 12.1 percentage points below it; low and high end bracket the measured number.
By their numbers in this assay, from the lowest: compound 1; then compound 2; then compounds 4 and 3 (each within the scatter of the next).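

In this assay, among the compounds shown here, this place on an aromatic carbon of the five-membered aromatic ring with 3 nitrogen accepts a five-membered aromatic ring with 1 hetero atom: 3-methylthiophen-2-yl in place of phenyl gives a number 0.5 percentage points lower from compound 3 to compound 4 (within the scatter), so phenyl is not the only group that holds the number at this level. The same group gives a number 10.9 percentage points higher from compound 2 to compound 4 (beyond the scatter) and a number 31.9 percentage points higher from compound 1 to compound 4 (beyond the scatter), so the lower numbers seen with 3-chlorophenyl and isoquinolin-5-yl do not extend to every group other than phenyl. No measurement at hand explains why phenyl and 3-methylthiophen-2-yl read alike.

The compounds shown leave open how thiophen-2-yl without its methyl group would read, and so which part of the entering group matters. Also open, on these data alone, is how a phenyl ring carrying an amine or a carboxylic acid would read in this place.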